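The source may report more compounds than this note shows. Statements on the series, on what has been measured and on what is new or still open speak of the compounds shown alone.

Measured so far in an ADME assay on microsomes from liver (Homo sapiens) for metabolic stability, with a stated time of 60 min; a higher number here means that more of the compound is left, a lower number that less of the compound is left:
Compound 1 `Cc1ccc(NC(=O)CC(CCN)c2nnc(CCCC(C)C)n2C2CC2)c(C)c1` gives 88%.
Compound 2 `Cc1ccc(NC(=O)C[C@H](CCC(=O)O)c2noc(-c3cc(CC(C)C)on3)c2C2CC2)c(Cl)c1` gives 74%.

Compound 2 stands lowest of these two numbers; its nearest neighbour is compound 1, whose number is higher by a gap that lies beyond the scatter. Compound 3 `Cc1ccc(NC(=O)C[C@H](CCC(=O)O)c2noc(-c3cc(C(F)(F)CC(C)C)on3)c2C2CC2)c(Cl)c1` has not yet been measured in this assay. It differs from compound 2 in one place: 1,1-difluoro-3-methylbutyl in place of isobutyl on an aromatic carbon. Within the data shown here, no step between measured compounds is known for this change, so the expectation rests on compound 2 alone. The step expected from this change, a number 6 percentage points higher from compound 2 to compound 3 (within the scatter), is small and upward, not clearly beyond the scatter. Compound 3 is therefore estimated at 80%, with a range from 62% to 94%.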

Compound 3, percent of the compound remaining: 78%
The estimate for compound 3 lay 2 percentage points above the measured number, within the range that was stated.
By their numbers in this assay, from the lowest: compounds 2, 3 and 1 (each within the scatter of the next, the first and the last beyond it).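

In this assay, the first change seen at this position, 1,1-difluoro-3-methylbutyl in place of isobutyl on the aromatic carbon next to the ring oxygen, gives a number 4 percentage points higher from compound 2 to compound 3 (within the scatter). This position therefore takes the larger chain with its two fluorine atoms without a step beyond the scatter in this read-out. Nothing at hand bears on the reason for this. On these data alone, it remains open whether a hydroxyl group, an amine or a longer chain without fluorine on this carbon would read alike, and whether the same change would read alike on the core of compound 1.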